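Chloro for fluoro on the pendant phenyl ring

The source may report more compounds than this note shows. Statements on the series, on what has been measured and on what is new or still open speak of the compounds shown alone.

Three amides sharing one core have been measured in an assay on cells for inhibition of sodium- and chloride-dependent glycine transporter 1 (Homo sapiens); a lower number here means that less compound is needed, a higher number that more compound is needed for the effect. Compound 1 `COc1cc(C(F)(F)F)cc(SC)c1C(=O)NC1(c2ccc(Cl)cc2)CCCN(C)C1` gives 28 nM, compound 2 `COc1cc(C(F)(F)F)cc(SC)c1C(=O)NC1(c2ccc(C)cc2)CCCN(C)C1` gives 230 nM, and compound 3 `COc1cc(C(F)(F)F)cc(SC)c1C(=O)NC1(c2cccc(F)c2)CCCN(C)C1` gives 48 nM. Compound 3 therefore stands second highest of the three numbers, separated by a 1.7-fold higher number from compound 1 to compound 3 (0.23 log units; within the scatter) and by a 4.8-fold lower number from compound 2 to compound 3 (0.68 log units; beyond the scatter). The swap of a methyl for a chloro on the aromatic carbon gave an 8.2-fold higher number from compound 1 to compound 2 (0.91 log units; beyond the scatter).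

Compound 4 `COc1cc(C(F)(F)F)cc(SC)c1C(=O)NC1(c2cccc(Cl)c2)CCCN(C)C1` differs from compound 3 by a single change: chloro in place of fluoro on an aromatic carbon. Within the data shown here, no measured pair shows chloro replacing fluoro directly. The nearest evidence is that compound 1, bearing a chloro on its phenyl ring, and compound 3, bearing a fluoro, sit within the scatter of each other. A chloro is thus expected to be at least as well tolerated as a fluoro here, so only a small step toward a lower number, or none beyond the scatter, is expected, a 1.4-fold lower number from compound 3 to compound 4 (0.14 log units; within the scatter). Compound 4 is estimated at 35 nM in this assay, with a range from 12 nM to 100 nM.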

Compound 4, half-maximal effective concentration: 25 nM
Beside the measured number, compound 4's estimate is 1.4-fold (0.15 log units) above it; low and high end bracket the measured number.
By their numbers in this assay, from the lowest: compounds 4, 1 and 3 (each within the scatter of the next); then compound 2.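

In this assay, the direct swap of chloro for fluoro on the aromatic carbon meta to a large group gives a 1.9-fold lower number from compound 3 to compound 4 (0.28 log units; within the scatter), so the two halogens cannot be told apart at this place. Putting 3-chlorophenyl in place of 4-chlorophenyl gives a 1.1-fold lower number from compound 1 to compound 4 (0.05 log units; within the scatter), so among these compounds the two placements of the chloro also cannot be told apart. Putting 3-chlorophenyl in place of 4-methylphenyl gives a 9.2-fold lower number from compound 2 to compound 4 (0.96 log units; beyond the scatter), which leaves compound 2 as the only one of the four set apart from the rest.

Nothing available gives a reason for any of these steps. Also open, on these data alone, is whether a 3-methylphenyl, or a larger group such as methoxy or trifluoromethyl at this place, would stay with the halogens or fall with compound 2.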